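Swapping dimethylamino for fluoro on compound 2

A few compounds are considered here, and "the series" means these few. Any claim that something is new, unique, unknown or untested is made for them only; others in the source may bear on it.

In a functional assay on HepG2 cells (Homo sapiens) for inhibition, read by MTT assay, with a stated time of 48 h (a lower number here means a stronger inhibitor, a higher number a weaker inhibitor), compound 2 `COc1cc(C(=O)/C=C/c2ccc(N(C)C)cc2)cc(OC)c1OC` gives 30000 nM, the highest of three numbers. Compound 1 `COc1cccc(/C=C/C(=O)c2cc(OC)c(OC)c(OC)c2)c1OC` gives 11500 nM and compound 3 `COc1cccc(/C=C/C(=O)c2cc(OC)c(OC)c(OC)c2)c1O` gives 13500 nM. Compound 4 `COc1cc(C(=O)/C=C/c2ccc(F)cc2)cc(OC)c1OC` has not yet been measured. It differs from compound 2 by fluoro in place of dimethylamino on an aromatic carbon, with fluoro in place of dimethylamino on an aromatic carbon. Within the data shown here, the only measured step, a 1.2-fold higher number from compound 1 to compound 3 (0.07 log units; within the scatter), concerns a different change, so it offers little direct guidance. Compound 1 and compound 3 lack dimethylamino and sit lower, but they also differ from compound 2 elsewhere, so this hint is weak. A modest move to a lower number is expected, an estimated 2.0-fold lower number from compound 2 to compound 4 (0.30 log units; within the scatter). For compound 4 the estimated value is 15000 nM, with an expected range of 6000 nM to 32000 nM.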

Compound 4, half-maximal inhibitory concentration: 22000 nM
Compound 4: middle estimate off by 1.5-fold (0.17 log units), on the low side; the range from low to high includes it.
By their numbers in this assay, from the lowest: compounds 1, 3, 4 and 2 (each within the scatter of the next, the first and the last beyond it).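

In this assay the fluoro for dimethylamino swap on this aromatic carbon, para to a large group, gives (a 1.4-fold lower number from compound 2 to compound 4 (0.13 log units; within the scatter)). Going from three heavy atoms to one and losing a hydrogen-bond acceptor therefore leaves compound 2 and compound 4 within the scatter of each other, so this change does not separate them. Nothing available explains this result. Still open, as far as these compounds go, is whether a group such as a carboxylic acid, a primary amine or a longer alkyl chain at this position would give a clearly different number.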